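Swapping Sulfur for Selenium in Compound 1

The compounds below may be only part of what the source reports. "The series", "measured", "known", "first", "only" and "open" are said of these compounds alone.

The study concerns acyl-imine compounds tested in a functional assay on HT-29 cells (Homo sapiens) for cytotoxicity, read by MTT assay, with a stated time of 72 h; a lower number here means that less compound is tolerated, a higher number that more compound is tolerated. Compound 1 `CS/C(=N\C(=O)c1ccno1)NC(=O)c1ccno1` carries a methylsulfanyl group on the carbon with a double bond to nitrogen. In this assay compound 1 gives only a limit, > 100000 nM, and no number. That is the limit of > 100000 nM in this assay, at which 2 of the 3 values shown sit. Compound 2 `C[Se]/C(=N\C(=O)c1cc(-c2ccccc2)nc2ccccc12)NC(=O)c1cc(-c2ccccc2)nc2ccccc12` is a selenium analogue built on a different core and gives 90700 nM in this assay. Compound 3 `O=C(/N=C(/NC(=O)c1cnc2ccccc2c1)[Se]Cc1ccccc1)c1cnc2ccccc2c1`, again on another core, also reaches only a limit in this assay, > 100000 nM. Going by the values given here, no two of the measured compounds differ in a single place, so no measured step is available, and the three values stand on their own.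

Compound 4 `C[Se]/C(=N\C(=O)c1ccno1)NC(=O)c1ccno1` has not yet been measured. It differs from compound 1 by a group of 2 heavy atoms (1 carbon, 1 selenium; no ring) in place of a group of 2 heavy atoms (1 carbon, 1 sulfur; no ring), on a carbon with a double bond to nitrogen. The expectation is that this change moves compound 4 at most within the usual scatter, in no clear direction, so the step of a number no higher from compound 1 to compound 4 (the limit leaves the size open) is expected to be small. Compound 4 is therefore estimated to give 100000 nM, within 40000 nM to 300000 nM, with a fair chance that only a limit is reported again.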

Compound 4, concentration lethal to 50% of the cells: > 100000 nM
Compound 4 was reported as a limit; the forecaster's own chance of this, stated with the estimate: 65%; the middle value lies on the limit itself.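

Going by these compounds alone, compound 1 and compound 4 both end as limits in this assay, so no step between them can be read: the limit of > 100000 nM in this assay, at which 3 of the 4 values shown sit.

The compounds shown leave open whether placing selenium instead of sulfur on the core of compound 1 changes the lethal concentration at all, and in which direction.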